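A Carbamate Cap on the Amide Nitrogen

The compounds below may be only part of what the source reports. "The series", "measured", "known", "first", "only" and "open" are said of these compounds alone.

Compound 2 `O=C(NCc1ccco1)c1ccc(CN2C(=O)c3ccccc3C2=O)cc1` carries a free amide hydrogen, and in a functional assay on RAW264.7 cells (Mus musculus) for inhibition (a lower number here means a stronger inhibitor, a higher number a weaker inhibitor), compound 2 gives 56000 nM. Compound 1 `CC(C)(C)OC(=O)N(Cc1ccco1)C(=O)c1ccc(CN2C(=O)c3ccccc3C2=O)cc1` differs from it by tert-butoxycarbonyl in place of hydrogen on an amide-type nitrogen; in this assay compound 1 gives 3450 nM. For the measured compounds named here, the resulting step of a 16-fold lower number from compound 2 to compound 1 (1.21 log units; beyond the scatter) is the only measured instance of this change in the set.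

Compound 3 `CNC(=O)c1ccc(CN2C(=O)c3ccccc3S2(=O)=O)cc1` is built on a different core; how that core differs from the core of compound 2 is not broken down here. In this assay compound 3 gives 37700 nM, a number that lies close to compound 2 and far from compound 1.

Compound 4 `CN(C(=O)OC(C)(C)C)C(=O)c1ccc(CN2C(=O)c3ccccc3S2(=O)=O)cc1` has not yet been measured. It differs from compound 3 by tert-butoxycarbonyl in place of hydrogen on an amide-type nitrogen, the same change that carries compound 2 to compound 1, and the place of the change is described in the same words for both pairs. What differs is the core on which it is made, and the data give no measure of how the two cores respond.

Compound 4 is expected to give 5000 nM in this assay, with a likely range from 1500 nM to 20000 nM. That expectation rests on the step of a 16-fold lower number from compound 2 to compound 1 (1.21 log units; beyond the scatter) applied to compound 3 at 37700 nM, tempered by the unresolved core difference. The estimated step of a 7.5-fold lower number from compound 3 to compound 4 (0.88 log units; beyond the scatter) is therefore expected to be somewhat smaller than the measured one.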

Compound 4, half-maximal inhibitory concentration: 42000 nM
Compound 4: middle estimate off by 8.4-fold (0.92 log units), on the low side, outside the stated range (above it).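

In this assay, tert-butoxycarbonyl in place of hydrogen on the amide-type nitrogen gives a 1.1-fold higher number from compound 3 to compound 4 (0.05 log units; within the scatter), so on this core the change leaves the number within the scatter. The large step seen on the core of compound 2 therefore did not carry over to the core of compound 3, and the two measured outcomes of the same change differ clearly: the same change on two cores in this assay, a 16-fold lower number (1.21 log units; beyond the scatter) from compound 2 to compound 1 and a 1.1-fold higher number (0.05 log units; within the scatter) from compound 3 to compound 4, 18-fold (1.26 log units) apart, beyond the scatter of two such steps This shows that the change cannot be treated as a fixed increment in this series, but it does not show what causes the difference, since the two pairs differ both in the core and in the other group on the amide-type nitrogen, and a single pair on each core cannot separate these two differences.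

The compounds shown leave open whether the outcome follows the core or that other nitrogen group, a question that a pair carrying the same nitrogen group on both cores could settle. They also leave open how a smaller cap such as methoxycarbonyl or acetyl, in place of the same hydrogen, would behave on either core.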